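This account rests on a few compounds, and the source may have more. Where it says the series, first, only, none or still open, it means among the compounds named here.

Compound 1 `Cc1nc(COc2ccc(/C=C3\SC(=O)NC3=O)cc2)cs1` and compound 2 `O=C1NC(=O)/C(=C/c2ccc(OCCSc3nnc(-c4ccccc4)o3)cc2)S1` share a core and were both tested in a functional assay on the whole organism (strain Wistar) with Rattus norvegicus as the target, with a stated time of 15 days, at a dose of 100 mg/kg by the oral route; a lower number here means a weaker effect, a higher number a stronger effect of the compound at the dose given. In this assay compound 1 gives 38.9%. In this assay compound 2 gives 33.1%, a value that lies within the usual scatter of compound 1, so no order between the two can be drawn. Compound 3 `O=C1NC(=O)/C(=C/c2ccc(OCCSc3nnc(Cc4ccccc4)o3)cc2)S1` is not yet measured; it differs from compound 2 only by benzyl in place of phenyl on an aromatic carbon. Among the compounds with values here, no measured pair in this set shows what such a change does, so the step from compound 2 to compound 3 is expected to be a number 0.1 percentage points lower from compound 2 to compound 3 (within the scatter), not beyond the scatter in either direction. In this assay compound 3 is therefore estimated to give about 33%, with a likely range from 20% to 48%.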

Compound 3, a percentage reported as activity, at one dose (the size of the read-out at that dose, not a potency): 34.6%
Compound 3: middle estimate off by 1.6 percentage points, on the low side; the measured number falls inside the stated range.
By their numbers in this assay, from the lowest: compounds 2, 3 and 1 (each within the scatter of the next).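

In this assay, benzyl in place of phenyl on the aromatic carbon gives a number 1.5 percentage points higher from compound 2 to compound 3 (within the scatter), the first step read at this position. This position therefore accepts the benzyl group for phenyl with no change that can be told from the scatter, at this single dose. Nothing available explains this result. The compounds shown leave open whether an amine, a carboxylic acid or a longer chain such as phenylethyl at this carbon would move the number beyond the scatter. They also leave open how substituents on the phenyl ring would act.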